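Trading an Aminophenyl for a Pyridinyl: an Estimate

This account rests on a few compounds, and the source may have more. Where it says the series, first, only, none or still open, it means among the compounds named here.

Measured so far:
compound 1 `COc1ccc(S(=O)(=O)N2CCc3cccc(-c4ccc(N)cc4)c32)cc1` — 301 nM
compound 2 `COc1ccc(S(=O)(=O)N2CCc3cccc(-c4ccc(N(C)C)cc4)c32)cc1` — 467 nM

In a functional assay on HT-29 cells (Homo sapiens) for inhibition, with a stated time of 72 h (on this read-out higher numbers stand for weaker inhibition and lower numbers for stronger inhibition), compound 1 gives 301 nM, the lowest of the two numbers shown, while compound 2 gives 467 nM; the step between them, a 1.6-fold higher number from compound 1 to compound 2 (0.19 log units; within the scatter), is within the scatter, so the two cannot be ordered. Compound 3 `COc1ccc(S(=O)(=O)N2CCc3cccc(-c4ccncc4)c32)cc1` has not been measured yet. It differs from compound 1 as follows: pyridin-4-yl in place of 4-aminophenyl on an aromatic carbon. Among the measured compounds shown here, only one measured step touches the same part of the molecule, a 1.6-fold higher number from compound 1 to compound 2 (0.19 log units; within the scatter), and it altered the amino group rather than removing the 4-aminophenyl ring altogether, so it bears on the new change only loosely. Since that small alteration hardly moved the number, a modest step is expected, if any, leaning toward weaker inhibition. For the measured compounds named here, the hydrogen-bond donor of compound 1 is absent in compound 3, and no measured compound shows what that loss does here. Compound 3 is therefore estimated at 600 nM, within 200 nM to 1800 nM, meaning an expected step of a 2.0-fold higher number from compound 1 to compound 3 (0.30 log units; within the scatter).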

Compound 3, half-maximal inhibitory concentration: 87.5 nM
The estimate for compound 3 lay 6.9-fold (0.84 log units) above the measured number; the measured number lies below the stated range.
By their numbers in this assay, from the lowest: compound 3; then compounds 1 and 2 (each within the scatter of the next).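

The aromatic carbon carrying this ring proved more responsive than the earlier pair suggested: altering only the amino group had stayed within the scatter, whereas exchanging the whole ring in this assay gives a 3.4-fold lower number from compound 1 to compound 3 (0.54 log units; beyond the scatter) and a 5.3-fold lower number from compound 2 to compound 3 (0.73 log units; beyond the scatter), both beyond the scatter. The exchange also removes the hydrogen-bond donor of the 4-aminophenyl group, and inhibition does not weaken, so that donor is not required for inhibition of this size in compound 3. Nothing at hand explains why the pyridin-4-yl group gives the lower number.

On these data alone, what an unsubstituted phenyl or a pyridin-3-yl group would give at this carbon remains open. The compounds shown therefore cannot separate the contribution of the ring nitrogen from that of losing the amino substituent.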